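The source may report more compounds than this note shows. Statements on the series, on what has been measured and on what is new or still open speak of the compounds shown alone.

Compound 1 `Cc1ccc(S(=O)(=O)n2cc(-c3cc(C(F)(F)F)c(C#N)c(-c4cn(S(=O)(=O)c5ccc(C)cc5)c5ccc(Br)cc45)n3)c3cc(Br)ccc32)cc1` gives 78000 nM in a functional assay on A549 cells (Homo sapiens) for cytotoxicity; on this read-out higher numbers stand for weaker inhibition and lower numbers for stronger inhibition. Compound 2 `Cc1ccc(S(=O)(=O)n2cc(-c3cc(C(F)(F)F)ccn3)c3cc(OCc4ccccc4)ccc32)cc1` reaches only the limit of this assay, > 100000 nM. Compound 3 `COc1ccc2c(-c3cc(C(F)(F)F)c(C#N)c(-c4cn(S(=O)(=O)c5ccc(C)cc5)c5cc(OC)ccc45)n3)cn(S(=O)(=O)c3ccc(C)cc3)c2c1` likewise reaches only a limit, > 100000 nM.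

Among the measured compounds shown here, compound 3 therefore stands at the limit of > 100000 nM in this assay, at which 2 of the 3 values shown sit, so no number of its own is known, and no step between measured compounds can be drawn from it. Compound 4 `COc1ccc2c(-c3cc(C(F)(F)F)cc(-c4cn(S(=O)(=O)c5ccc(C)cc5)c5cc(OC)ccc45)n3)cn(S(=O)(=O)c3ccc(C)cc3)c2c1` differs from compound 3 by a single change: hydrogen in place of cyano on an aromatic carbon. For the measured compounds named here, with no measured step to lean on, no shift beyond the usual scatter is expected in this assay in either direction. The step of a number no higher from compound 3 to compound 4 (the limit leaves the size open) is the expected outcome. Compound 4 is expected to give about 100000 nM, most plausibly between 40000 nM and 300000 nM, with a strong chance that this assay again reports only a limit.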

Compound 4, half-maximal inhibitory concentration: 1700 nM
Compound 4: middle estimate off by 59-fold (1.77 log units), on the high side, and the stated range ends above it.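

Swapping cyano for hydrogen on this aromatic carbon, ortho to a trifluoromethyl group, gives an at least 58-fold lower number from compound 3 to compound 4 (1.76 log units; beyond the scatter) in this assay. Among the compounds shown here, this is the first measured sign that this single position matters, with hydrogen here going with stronger inhibition than cyano. The true size of the step stays unknown, as the value of compound 3 is only a limit: the limit of > 100000 nM in this assay, at which 2 of the 4 values shown sit.

Going by these compounds, whether a methyl group, a chlorine atom or an amine at this position would behave like hydrogen or like cyano remains open. So does whether the same change would lower the number on the core of compound 1.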